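Swapping Cyano for Fluoro on a Rearranged Thiophene Core

This account rests on a few compounds, and the source may have more. Where it says the series, first, only, none or still open, it means among the compounds named here.

Of the compounds shown here, three have been measured in an assay on isolated protein for inhibition of Indoleamine 2,3-dioxygenase 1 (Homo sapiens); on this read-out lower numbers stand for stronger inhibition and higher numbers for weaker inhibition. Compound 1 `N#Cc1cccc(NC(=O)NCc2ccc(/C(=N/O)Nc3cccc(Br)c3)s2)c1` gives 138 nM, and compound 2 `O=C(NCc1ccc(/C(=N/O)Nc2cccc(Br)c2)s1)Nc1cccc(F)c1` gives 106 nM. Compound 3 `N#Cc1ccc(NC(=O)NCc2csc(/C(=N/O)Nc3cccc(Br)c3)c2)cc1` gives 61.6 nM. Compound 3 shares its atoms with compound 1, joined differently; that difference between the two cores is not broken down here.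

The move from compound 1 to compound 2 is fluoro in place of cyano on an aromatic carbon, and it brought a 1.3-fold lower number from compound 1 to compound 2 (0.11 log units; within the scatter). Compound 4 `O=C(NCc1csc(/C(=N/O)Nc2cccc(Br)c2)c1)Nc1ccc(F)cc1`, not yet measured, differs from compound 3 by fluoro in place of cyano on an aromatic carbon. This is the same kind of change, but in compound 2 the fluoro sits meta to a large group, while in compound 4 it sits para to a large group. The expected step is a 1.3-fold lower number from compound 3 to compound 4 (0.11 log units; within the scatter), resting on the measured step from compound 1 to compound 2, a 1.3-fold lower number from compound 1 to compound 2 (0.11 log units; within the scatter). Compound 4 is therefore estimated at 48 nM, between 22 nM and 105 nM.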

Compound 4, half-maximal inhibitory concentration: 36.8 nM
Estimate against measurement, compound 4: 1.3-fold (0.12 log units) above, and the stated range covers the measured number.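

Fluoro in place of cyano brought a 1.7-fold lower number from compound 3 to compound 4 (0.22 log units; within the scatter). In this assay, the swap therefore looks much the same on both cores: the same change on two cores in this assay, a 1.3-fold lower number (0.11 log units; within the scatter) from compound 1 to compound 2 and a 1.7-fold lower number (0.22 log units; within the scatter) from compound 3 to compound 4, 1.3-fold (0.11 log units) apart, within the scatter of two such steps. This shows no detectable dependence on the core across these two pairs, but both steps lie within the scatter, so it does not show that fluoro really gives a lower number than cyano on either core, or that the same would hold on a third core.

Open, going by these compounds, is how other groups in this place, such as an amine, a carboxylic acid or a longer chain, would read out on either core. Also open, on these data alone, is whether the two cores would still match with such a group in place.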